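The compounds below may be only part of what the source reports. "The series", "measured", "known", "first", "only" and "open" are said of these compounds alone.

Compound 1 `CCc1cc(Cl)c(S(C)(=O)=O)cc1C(=O)N=C(N)N`: 63 nM in a functional assay for inhibition of sodium/hydrogen exchanger (Oryctolagus cuniculus); on this read-out lower numbers stand for stronger inhibition and higher numbers for weaker inhibition.
Compound 2 `CCc1cc(Br)c(S(C)(=O)=O)cc1C(=O)N=C(N)N`: 41 nM.
Compound 3 `CCC(C)c1cc(C)c(C(=O)N=C(N)N)cc1S(C)(=O)=O`: 8 nM.

Compound 3 stands lowest of the three numbers, and its gaps to compound 2 and to compound 1 both lie beyond the scatter. Compound 4 is `Cc1cc(-c2ccccc2)c(S(C)(=O)=O)cc1C(=O)N=C(N)N`, not yet measured. The change from compound 3 to compound 4 is phenyl in place of sec-butyl on an aromatic carbon. Within the data shown here, the only step that has been measured, a 1.5-fold lower number from compound 1 to compound 2 (0.19 log units; within the scatter), swaps one halogen for another and lies within the scatter; it does not bear on replacing sec-butyl with phenyl. Among the measured compounds shown here, no measured pair speaks to that change, so the estimate rests on compound 3 alone and is wide. Compound 4 is expected to show a 3.8-fold higher number from compound 3 to compound 4 (0.57 log units; beyond the scatter), toward a higher number. Compound 4 is estimated at 30 nM, between 6 nM and 150 nM.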

Compound 4, half-maximal inhibitory concentration: 19 nM
For compound 4 the middle estimate is 1.6-fold (0.20 log units) above the measured one; low and high end bracket the measured number.
By their numbers in this assay, from the lowest: compound 3; then compound 4; then compounds 2 and 1 (each within the scatter of the next).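

Replacing sec-butyl with phenyl on the aromatic carbon ortho to the methylsulfonyl group gives a 2.4-fold higher number from compound 3 to compound 4 (0.38 log units; beyond the scatter) in this assay. Unlike the halogen swap at this position, this change moves the number beyond the scatter, yet only modestly, so the position accepts a six-membered aromatic ring of carbon only at a small cost. Nothing available offers an explanation for this step.

The compounds shown leave open how an amine or a phenoxy group at this position would compare with sec-butyl and phenyl. They also leave open whether the step holds with ethyl in place of the methyl group.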